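A larger group on the amine nitrogen

This account rests on a few compounds, and the source may have more. Where it says the series, first, only, none or still open, it means among the compounds named here.

In a functional assay on MCF7 cells (Homo sapiens) for inhibition, read by MTT assay, with a stated time of 48 h (a lower number here means a stronger inhibitor, a higher number a weaker inhibitor), compound 1 (`CCOC(=O)C1=C(N/C=N/c2nnc(S(N)(=O)=O)s2)Nc2[nH]nc(C)c2C1c1ccc(N(C)C)cc1`) gives 34500 nM and compound 2 (`CCOC(=O)C1=C(N/N=C(/Cl)C#N)Nc2[nH]nc(C)c2C1c1ccc(N(C)C)cc1`) gives 23200 nM, so the two stand within the scatter of each other. Compound 3 (`CCOC(=O)C1=C(N/C=N/c2ccc([N+](=O)[O-])cc2)Nc2[nH]nc(C)c2C1c1ccc(N(C)C)cc1`) differs from compound 2 by a group of 11 heavy atoms (7 carbon, 2 nitrogen, 2 oxygen; one six-membered aromatic ring of carbon only) in place of a group of 5 heavy atoms (2 carbon, 2 nitrogen, 1 chlorine; no ring), on an amine nitrogen. Going by the values given here, the only measured step bearing on this change, a 1.5-fold lower number from compound 1 to compound 2 (0.17 log units; within the scatter), exchanged groups of similar sizes on that amine nitrogen and stayed within the scatter. Among the compounds with values here, no measured compound carries a six-membered aromatic ring of carbon only on that nitrogen, so the range stays wide. The expected step, a 1.2-fold higher number from compound 2 to compound 3 (0.08 log units; within the scatter), is none beyond the scatter. For compound 3 the estimate is 28000 nM, with an expected range of 12000 nM to 60000 nM.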

Compound 3, half-maximal inhibitory concentration: 58600 nM
For compound 3 the middle estimate is 2.1-fold (0.32 log units) below the measured one, and the stated range covers the measured number.
By their numbers in this assay, from the lowest: compounds 2, 1 and 3 (each within the scatter of the next, the first and the last beyond it).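

On the amine nitrogen, the series now has a step beyond the scatter in this assay (a 2.5-fold higher number from compound 2 to compound 3 (0.40 log units; beyond the scatter)), so exchanging these groups can change the number measurably. The step between the two ring-bearing groups, with 4-nitrophenyl in place of 5-sulfamoyl-1,3,4-thiadiazol-2-yl on a double-bonded nitrogen (a 1.7-fold higher number from compound 1 to compound 3 (0.23 log units; within the scatter)), stays within the scatter, so these two are not separated. Open, from the compounds shown here alone, is how a morpholine or a carboxylic acid on that nitrogen would read in this assay. No measurement shown accounts for the step from compound 2 to compound 3.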